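The source may hold more compounds than are shown below. What is called first, only, known or untested is meant among the compounds shown, and "the series" means these compounds.

Measured so far:
Compound 1, `CN(C)CCC(NC(=O)C#Cc1ccccc1)c1ccc2ccccc2c1`: in a functional assay on NIH3T3 cells for agonist activity at Urotensin-2 receptor (Homo sapiens), with a stated time of 5 days (on this read-out lower numbers stand for an effect already at smaller amounts and higher numbers for an effect only at larger amounts of compound), compound 1 gives 457 nM.
Compound 2, `COc1ccc(/C=C/C(=O)NC(CCN(C)C)c2ccc(C)cc2)cc1`: in this assay compound 2 gives 2000 nM.
Compound 3, `CN(C)CCC(NC(=O)/C=C/c1ccccc1)c1ccc2ccccc2c1`: in this assay compound 3 gives 589 nM.

Compound 2 stands with the highest number of the three in this assay; the nearest to it is compound 3 and the furthest is compound 1, both separated from compound 2 beyond the scatter. For the measured compounds named here, the only step between compounds differing in one place is a 1.3-fold higher number from compound 1 to compound 3 (0.11 log units; within the scatter), which concerns the group on the carbonyl carbon and lies within the scatter.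

Compound 4, `COc1ccc(/C=C/C(=O)NC(CCN(C)C)c2ccc(Cl)cc2)cc1`, is not yet measured in this assay. It differs from compound 2 in one place: chloro in place of methyl on an aromatic carbon. Going by the values given here, no measured pair touches this position, and the one known step does not bear on it, so the size of the coming step cannot be read from the data. The expected step is a 1.1-fold lower number from compound 2 to compound 4 (0.05 log units; within the scatter), within the scatter. Compound 4 is estimated at 1800 nM, between 600 nM and 5500 nM.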

Compound 4, half-maximal effective concentration: 513 nM
Compound 4: middle estimate off by 3.5-fold (0.55 log units), on the high side, outside the stated range (below it).
By their numbers in this assay, from the lowest: compounds 1, 4 and 3 (each within the scatter of the next); then compound 2.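

In this assay, for the compounds shown here, the change from 4-methylphenyl to 4-chlorophenyl gives a 3.9-fold lower number from compound 2 to compound 4 (0.59 log units; beyond the scatter) and is the first step at this position, on an aromatic carbon para to a large group. The number therefore responds here to the exchange of a single heavy atom, with one heavy atom leaving, one entering, and no change in the counted hydrogen-bond donors, acceptors or net charge. Nothing at hand accounts for the size of this step.

The compounds shown leave open how fluoro, bromo, methoxy or trifluoromethyl would fare at this position, since methyl and chloro are only two points. Going by these compounds alone, also open is whether the same exchange gives a step of similar size when the group on the carbonyl carbon is 2-phenylethynyl rather than the one in compound 2 and compound 4.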